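Dropping One Fluorine from a Difluorophenyl Amide

The source may report more compounds than this note shows. Statements on the series, on what has been measured and on what is new or still open speak of the compounds shown alone.

Compound 1 `Cc1ccc(C2=NOC(C)(C)C2=O)cc1-c1cnc(NC(=O)c2c(F)cccc2F)cn1` has the lowest number of the three measured compounds. In an assay on Jurkat T cells for inhibition of interleukin-2 (Homo sapiens), read by ELISA, with stated times of 10 min and 24 h (on this read-out higher numbers stand for weaker inhibition and lower numbers for stronger inhibition), compound 1 gives 34 nM. Compound 2 `Cc1c(C2=NOC(C)(C)C2=O)cccc1-c1cnc(NC(=O)c2c(F)cccc2F)cn1` gives 55 nM, which sits within the scatter of compound 1, so the two cannot be told apart. Compound 3 `Cc1ccc(C2=NOC(C)(C)C2=O)cc1-c1cnc(C(=O)Nc2c(F)cccc2F)cn1` gives 150 nM, beyond the scatter, and is therefore a weaker inhibitor than compound 1. Compound 4 `Cc1ccc(C2=NOC(C)(C)C2=O)cc1-c1cnc(NC(=O)c2ccccc2F)cn1` differs from compound 1 in one place: hydrogen in place of fluoro on an aromatic carbon. Among the measured compounds shown here, no measured pair shows this change, so the expectation rests on the change alone. A small shift toward weaker inhibition, close to the edge of the scatter, is expected: a 1.8-fold higher number from compound 1 to compound 4 (0.25 log units; within the scatter). Compound 4 is estimated to give 60 nM, with a range from 25 nM to 150 nM.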

Compound 4, half-maximal inhibitory concentration: "not active" (no number reported)
Compound 4 has no reported number here, so the estimate cannot be set against anything.
By their numbers in this assay, from the lowest: compounds 1 and 2 (each within the scatter of the next); then compound 3.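

Among the compounds shown here, compound 4 is reported as not active, without a number, so no step from compound 1 to compound 4 can be read. Nothing shown accounts for this result. The compounds shown leave open how large the effect of replacing this fluoro with hydrogen is.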